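The source may hold more compounds than are shown below. What is called first, only, known or untested is meant among the compounds shown, and "the series" means these compounds.

Of the compounds shown here, three built on one shared core have so far been tested in an assay on HEK293 cells for displacement of a labelled ligand from NPC1-like intracellular cholesterol transporter 1 (Homo sapiens); on this read-out higher numbers stand for weaker inhibition and lower numbers for stronger inhibition. Compound 1 `CC(C)(C)c1ccc(C(=O)N2CCC3(CC2)C(=O)N(CC(=O)NCCO)CN3c2ccccc2)cc1` gives 1000 nM. Compound 2 `CC(C)(C)c1ccc(C(=O)N2CCC3(CC2)C(=O)N(CC(=O)NCCC(=O)O)CN3c2ccccc2)cc1` gives 11400 nM, and compound 3 `CC(C)(C)c1ccc(C(=O)N2CCC3(CC2)C(=O)N(CC(=O)N2CCN(S(C)(=O)=O)CC2)CN3c2ccccc2)cc1` gives 19000 nM. Compound 3 thus has the highest of the three numbers; its nearest neighbour is compound 2, and that gap is within the scatter, whereas the step of a 19-fold higher number from compound 1 to compound 3 (1.28 log units; beyond the scatter) is a large move toward weaker inhibition.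

The step followed here leads to compound 4 `CC(C)(C)c1ccc(C(=O)N2CCC3(CC2)C(=O)N(CC(=O)N2CCCC(O)C2)CN3c2ccccc2)cc1`, which differs from compound 3 in a single place: 3-hydroxypiperidin-1-yl in place of 4-(methylsulfonyl)piperazin-1-yl on a carbonyl carbon. For the measured compounds named here, the closest precedent is the step of a 19-fold higher number from compound 1 to compound 3 (1.28 log units; beyond the scatter). There, the (2-hydroxyethyl)amino group of compound 1 was exchanged for the 4-(methylsulfonyl)piperazin-1-yl group of compound 3, and the number rose sharply. Compound 4 brings back a group carrying a hydroxy, now as 3-hydroxypiperidin-1-yl, so a move back toward the number of compound 1 is expected, though the exchange is not an exact reversal, and the step of a 1.7-fold higher number from compound 2 to compound 3 (0.22 log units; within the scatter) shows that not every change at this position shifts the number beyond the scatter. The step of a 4.8-fold lower number from compound 3 to compound 4 (0.68 log units; beyond the scatter) is therefore expected to lower the number. Compound 4 is estimated at 4000 nM, with a range from 1500 nM to 12000 nM.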

Compound 4, half-maximal inhibitory concentration: 12200 nM
Estimate against measurement, compound 4: 3.1-fold (0.48 log units) below, and the stated range ends below it.
By their numbers in this assay, from the lowest: compound 1; then compounds 2, 4 and 3 (each within the scatter of the next).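

Bringing a hydroxy group back at this carbonyl carbon does not by itself bring back the number of compound 1: 3-hydroxypiperidin-1-yl still leaves a large gap (a 12-fold higher number from compound 1 to compound 4 (1.09 log units; beyond the scatter)). It also barely separates from the groups already tried, either from 4-(methylsulfonyl)piperazin-1-yl (a 1.6-fold lower number from compound 3 to compound 4 (0.19 log units; within the scatter)) or from (2-carboxyethyl)amino (a 1.1-fold higher number from compound 2 to compound 4 (0.03 log units; within the scatter)), so three quite different groups now sit within the scatter of one another, and only the (2-hydroxyethyl)amino group of compound 1 stands apart. Compound 4 therefore goes against any simple reading that a hydroxy group alone marks the stronger compounds here, and nothing available explains what sets compound 1 apart.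

As far as these compounds go, what remains open is whether the difference lies in the open chain with its amide hydrogen or in the ring, which a plain (2-methoxyethyl)amino group, a longer (3-hydroxypropyl)amino chain or a 4-hydroxypiperidin-1-yl ring could help to separate. From the compounds shown here alone, it is also open whether a basic group such as a (2-aminoethyl)amino chain at this carbonyl carbon would behave like compound 1 or like the other three.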